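Anilino replaces an aryl group on the shared core

This account rests on a few compounds, and the source may have more. Where it says the series, first, only, none or still open, it means among the compounds named here.

In a functional assay on A549 cells (Homo sapiens) for antiproliferative activity, read by MTT assay, with a stated time of 72 h (a lower number here means a stronger inhibitor, a higher number a weaker inhibitor), compound 1 (`COc1cc(C(=O)c2sc3ccccc3c2-c2ccc(F)cc2)cc(OC)c1OC`) gives 3200 nM and compound 2 (`COc1cc(C(=O)c2sc3ccccc3c2-c2ccc(SC)cc2)cc(OC)c1OC`) gives 5400 nM on the shared core, while compound 3 (`COc1ccc(-c2c(C(=O)c3cc(OC)c(OC)c(OC)c3)sc3ccccc23)c(OC)c1`) gives 5800 nM and stands level with both. Compound 4 (`COc1cc(C(=O)c2sc3ccccc3c2Nc2ccccc2)cc(OC)c1OC`) carries anilino in place of 2,4-dimethoxyphenyl on an aromatic carbon. Within the data shown here, three measured steps bear on this change, all of them exchanges of the aryl group at the same place or of a group on it (a 1.8-fold higher number from compound 1 to compound 3 (0.26 log units; within the scatter) and a 1.1-fold higher number from compound 2 to compound 3 (0.03 log units; within the scatter) and a 1.7-fold higher number from compound 1 to compound 2 (0.23 log units; within the scatter)). Among the measured compounds shown here, none of them brings in anilino, so the data hold no direct precedent for it. As far as these compounds go, no step beyond the scatter is therefore expected in this assay and the direction remains open. The estimated step, placed amid the three measured numbers, is a 1.3-fold lower number from compound 3 to compound 4 (0.10 log units; within the scatter) and it carries wide uncertainty. For compound 4 the estimated value is 4600 nM with an expected range from 1300 nM to 15000 nM in this measurement.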

Compound 4, half-maximal inhibitory concentration: 3000 nM
Beside the measured number, compound 4's estimate is 1.5-fold (0.19 log units) above it; low and high end bracket the measured number.
By their numbers in this assay, from the lowest: compounds 4, 1, 2 and 3 (each within the scatter of the next).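

In this assay, the aromatic carbon of the five-membered ring tolerates anilino as well as it tolerates the aryl groups, with a 1.9-fold lower number from compound 3 to compound 4 (0.29 log units; within the scatter), a 1.8-fold lower number from compound 2 to compound 4 (0.26 log units; within the scatter) and a 1.1-fold lower number from compound 1 to compound 4 (0.03 log units; within the scatter). Anilino thus brings a ring joined through nitrogen and a hydrogen-bond donor, which none of the three aryl groups has, yet all four compounds stay within the scatter of one another, and no order among them can be claimed. Nothing available here accounts for this level result.

As far as these compounds go, it remains open whether a plain amino group, a morpholine or a benzylamino group at this position would give a step beyond the scatter. Equally open, from the compounds shown here alone, is whether a methoxy or fluoro substituent on the anilino ring would shift the number.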